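Trimming the Methoxy from the Hydrazone Aryl Ring

The source may hold more compounds than are shown below. What is called first, only, known or untested is meant among the compounds shown, and "the series" means these compounds.

Going by the values given here, compound 2 `COc1ccc(/C=N/NC(=O)Nc2ccc(Oc3ccnc(-c4nncn4CCN(C)C)c3)c(F)c2)cc1O` shows the highest of the two numbers recorded in a functional assay on NCI-H460 cells (Homo sapiens) for cytotoxicity, read by MTT assay, with a stated time of 72 h; a lower number here means a stronger inhibitor, a higher number a weaker inhibitor: compound 2 gives 620 nM, whereas compound 1 `CN(C)CCn1cnnc1-c1cc(Oc2ccc(NC(=O)N/N=C/c3cccc(Cl)c3Cl)cc2F)ccn1` gives 72 nM, the single step observed being an 8.6-fold higher number from compound 1 to compound 2 (0.94 log units; beyond the scatter). Compound 3 `CN(C)CCn1cnnc1-c1cc(Oc2ccc(NC(=O)N/N=C/c3cccc(O)c3)cc2F)ccn1` differs from compound 2 by hydrogen in place of methoxy on an aromatic carbon. Among the compounds with values here, that change sits on the same aryl ring as the one step seen, yet no pair in hand removes a methoxy alone, so the guidance is indirect, and the expected step of a 1.6-fold lower number from compound 2 to compound 3 (0.19 log units; within the scatter) is small. Compound 3 is therefore estimated at 400 nM, with a range from 150 nM to 1200 nM.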

Compound 3, half-maximal inhibitory concentration: 780 nM
Compound 3: the middle estimate sits 2.0-fold (0.29 log units) below what was measured; low and high end bracket the measured number.
By their numbers in this assay, from the lowest: compound 1; then compounds 2 and 3 (each within the scatter of the next).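

In this assay, hydrogen in place of methoxy, on the carbon ortho to a hydroxy group, gives a step within the scatter (a 1.3-fold higher number from compound 2 to compound 3 (0.10 log units; within the scatter)), so this position shows no readable preference between the two, which the earlier pair could not separate. The 3-hydroxyphenyl ring also stays well short of the 2,3-dichlorophenyl ring (an 11-fold higher number from compound 1 to compound 3 (1.03 log units; beyond the scatter)). No supporting measurement accounts for either step. As far as these compounds go, what an amine or an ethoxy group would do at this position remains open, as does which chlorine of compound 1 matters.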